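Swapping fluoro for methyl on compound 1

The source may report more compounds than this note shows. Statements on the series, on what has been measured and on what is new or still open speak of the compounds shown alone.

Of the compounds shown here, two have been measured so far in an ADME assay on Vero cells (Chlorocebus sabaeus) for cytotoxicity, read by MTT assay, with a stated time of 72 h; on this read-out lower numbers stand for higher toxicity in this test and higher numbers for lower toxicity in this test. Compound 1 `COc1c(N2C[C@H]3CCCN(Cc4cn(CCCN5C(=O)C(=O)c6cc(F)ccc65)nn4)[C@H]3C2)c(F)cc2c(=O)c(C(=O)O)cn(C3CC3)c12` gives 16 ug/mL, the higher of the two numbers, and compound 2 `CCO/N=C1/C(=O)N(CCCn2cc(CN3CCC[C@@H]4CN(c5c(F)cc6c(=O)c(C(=O)O)cn(C7CC7)c6c5OC)C[C@@H]43)nn2)c2ccc(C)cc21` gives 4 ug/mL, a gap that lies beyond the usual scatter. Compound 1 therefore stands at the low-toxicity end of this small set. Compound 3 `COc1c(N2C[C@H]3CCCN(Cc4cn(CCCN5C(=O)C(=O)c6cc(C)ccc65)nn4)[C@H]3C2)c(F)cc2c(=O)c(C(=O)O)cn(C3CC3)c12` keeps the core of compound 1 but has methyl in place of fluoro on an aromatic carbon . Going by the values given here, no two measured compounds differ in one place alone, so the data offer no direct measure of this exchange. The estimated change, a 1.3-fold lower number from compound 1 to compound 3 (0.12 log units; within the scatter), is expected to be slightly toward a lower number and to stay within the scatter. In this assay compound 3 is expected at 12 ug/mL, with an estimated range from 4 ug/mL to 32 ug/mL overall.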

Compound 3, half-maximal cytotoxic concentration: 32 ug/mL
Beside the measured number, compound 3's estimate is 2.7-fold (0.43 log units) below it; measured number inside the range.
By their numbers in this assay, from the lowest: compound 2; then compounds 1 and 3 (each within the scatter of the next).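

In this assay, going by these compounds alone, the exchange of fluoro for methyl on the aromatic carbon gives a 2.0-fold higher number from compound 1 to compound 3 (0.30 log units; within the scatter), which is the first direct reading of this change on the shared core. Within the data shown here, at this position, meta to a fused ring and para to a fused ring, compound 1 and compound 3 therefore cannot be told apart by this read-out, and the single exchange gives no sign of a shift in either direction. The data offer nothing that would explain this result.

On these data alone, whether another group at this position, such as methoxy, an amine or a carboxylic acid, would move the number beyond the scatter remains open. As far as these compounds go, it is also open whether fluoro and methyl would read alike here if the rest of the molecule were different.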